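The source may hold more compounds than are shown below. What is called first, only, known or untested is meant among the compounds shown, and "the series" means these compounds.

Compound 1 `CCCCCCCCCCCCCCCCc1c(C)c(N(C)C)nc(C)c1O` and compound 2 `CCCCCCCCCCc1nc(N(C)C)c(C)c(C)c1O` share a core that carries a hydroxyl group, a dimethylamino group, two methyl groups and one long saturated chain. In a functional assay on cells (Lymphocyte, Homo sapiens), read by trypan blue exclusion, with a stated time of 16 h, tested at 2.5 uM (on this read-out higher numbers stand for a stronger effect at the one concentration tested and lower numbers for a weaker effect), compound 1 gives 84% and compound 2 gives 87%. These two numbers lie within the usual scatter of one another, so on what has been measured compound 2 cannot be set apart from compound 1, even though its number is the higher of the two shown.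

Compound 3 `CCCCCCCCCCCCCCCCc1nc(N(C)C)c(C)c(C)c1O` has not yet been measured. It differs from compound 2 by hexyl in place of hydrogen on a saturated chain carbon, ten or more bonds along the chain from an aromatic carbon. The two measured compounds already differ in the length of their chain and in where the groups sit on the core, yet compound 1 gives 84% and compound 2 gives 87%, a gap within the scatter. Lengthening the chain of compound 2 is therefore expected to produce no step beyond the scatter in this assay, the expected step being a number 1 percentage points lower from compound 2 to compound 3 (within the scatter). Compound 3 is estimated to give 86%, with a range from 72% to 96%.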

Compound 3, a percentage reported as activity, at one concentration (the size of the read-out at that concentration, not a potency): 92%
Compound 3: the middle estimate sits 6 percentage points below what was measured; the measured number falls inside the stated range.
By their numbers in this assay, from the lowest: compounds 1, 2 and 3 (each within the scatter of the next).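

Within the data shown here, compound 2 and compound 3 form the first pair here that differs in one place only, so the effect of this single change can be read directly. In this assay, hexyl in place of hydrogen on a saturated chain carbon, ten or more bonds along the chain from an aromatic carbon, gives a number 5 percentage points higher from compound 2 to compound 3 (within the scatter), which means that the two compounds cannot be told apart on this read-out and that this place on the chain accepts the added hexyl without a measurable loss of effect. Nothing shown here accounts for this result, and no separate measurement bears on it.

The compounds shown leave open whether a still longer chain, or a chain ending in an amine or a carboxylic acid, would keep a number close to those of compound 2 and compound 3 in this assay. With a single concentration tested, they also leave open whether compound 2 and compound 3 would separate at lower concentrations, where a difference hidden at this one concentration might appear.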